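Adding a second chloro to the benzamide of compound 3

The source may hold more compounds than are shown below. What is called first, only, known or untested is meant among the compounds shown, and "the series" means these compounds.

Compound 1, `O=C(NC1CCN(c2ncnc3[nH]ncc23)CC1)c1ccc(F)cc1`, gives 4540 nM in an assay on isolated protein for inhibition of serine/threonine-protein kinase PAK 1 (Homo sapiens), read by ADP-Glo, with a stated time of 40 min; on this read-out lower numbers stand for stronger inhibition and higher numbers for weaker inhibition.
Compound 2, `O=C(NC1CCN(c2ncnc3[nH]ncc23)CC1)c1ccc(Br)cc1`, gives 16400 nM.
Compound 3, `O=C(NC1CCN(c2ncnc3[nH]ncc23)CC1)c1ccccc1Cl`, gives 5240 nM.

Compound 3 stands second highest of the three numbers: a 1.2-fold higher number from compound 1 to compound 3 (0.06 log units; within the scatter), while a 3.1-fold lower number from compound 2 to compound 3 (0.50 log units; beyond the scatter). Compound 4, `O=C(NC1CCN(c2ncnc3[nH]ncc23)CC1)c1cccc(Cl)c1Cl`, differs from compound 3 by chloro in place of hydrogen on an aromatic carbon. For the measured compounds named here, no measured step adds a halogen to an already halogenated ring; the nearest comparisons, a 3.6-fold higher number from compound 1 to compound 2 (0.56 log units; beyond the scatter) and a 3.1-fold lower number from compound 2 to compound 3 (0.50 log units; beyond the scatter), show that changing the halogen pattern moves this assay modestly in either direction. A step of at most modest size is therefore expected, with no clear direction. Compound 4 is estimated at 5000 nM, within 1500 nM to 16000 nM. The expected step is a 1.0-fold lower number from compound 3 to compound 4 (0.02 log units; within the scatter).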

Compound 4, half-maximal inhibitory concentration: 4170 nM
For compound 4 the middle estimate is 1.2-fold (0.08 log units) above the measured one, within the range that was stated.
By their numbers in this assay, from the lowest: compounds 4, 1 and 3 (each within the scatter of the next); then compound 2.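

In this assay, chloro in place of hydrogen on the ring of compound 3 adds a halogen to an already halogenated ring and stays within the scatter (a 1.3-fold lower number from compound 3 to compound 4 (0.10 log units; within the scatter)). The 2,3-dichlorophenyl amide is likewise within the scatter of the 4-fluorophenyl amide (a 1.1-fold lower number from compound 1 to compound 4 (0.04 log units; within the scatter)), and it stands clear of the 4-bromophenyl amide (a 3.9-fold lower number from compound 2 to compound 4 (0.59 log units; beyond the scatter)), so this position accepts a second chloro without the weaker number of compound 2. Nothing available explains this result. Open, as far as these compounds go, is how a methoxy group, an amine or a carboxylic acid at this position would read.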